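A few compounds are considered here, and "the series" means these few. Any claim that something is new, unique, unknown or untested is made for them only; others in the source may bear on it.

Measured in a functional assay on OVCAR-3 cells (Homo sapiens) for antiproliferative activity, read by MTT assay, with a stated time of 24 h; on this read-out higher numbers stand for weaker inhibition and lower numbers for stronger inhibition:
- compound 1 `O=C(NNc1ccccc1Cl)c1ccc(NS(=O)(=O)c2cnc(O)nc2O)cc1`: 7230 nM
- compound 2 `Cc1cccc(NNC(=O)c2cccc(NS(=O)(=O)c3cnc(O)nc3O)c2)c1`: > 20000 nM
- compound 3 `O=C(NNc1cccc(Cl)c1)c1ccccc1NS(=O)(=O)c1cnc(O)nc1O`: 5520 nM

Compound 1 gives 7230 nM and compound 3 gives 5520 nM, two values within the usual scatter of each other. Compound 2 reads > 20000 nM, which is a limit and not a number. Going by the values given here, compound 1 therefore stands level with compound 3, the only other compound with a true number.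

Compound 4 `Cc1ccc(C(=O)NNC(=O)c2ccc(NS(=O)(=O)c3cnc(O)nc3O)cc2)cc1` has not yet been measured. It carries (4-methylphenyl)carbonyl in place of 2-chlorophenyl on an amine nitrogen. Among the compounds with values here, no measured pair shows this change, so only a modest step toward weaker inhibition in this assay is expected, a 1.2-fold higher number from compound 1 to compound 4 (0.10 log units; within the scatter). The estimate for compound 4 is 9000 nM, with an expected range of 3000 nM to 25000 nM.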

Compound 4, half-maximal inhibitory concentration: > 20000 nM
Compound 4 ended at the assay's limit; the forecaster's own chance of this, stated with the estimate: 20%; middle value at least 2.2-fold (0.34 log units) from the limit.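

In this assay, compound 4 gives > 20000 nM, which is a limit of the assay and not a number. Even so, this is the first change at this amine nitrogen that can be read, and putting (4-methylphenyl)carbonyl in place of 2-chlorophenyl gives an at least 2.7-fold higher number from compound 1 to compound 4 (0.44 log units; beyond the scatter). The full size of this step cannot be read: the limit of > 20000 nM in this assay, at which 2 of the 4 values shown sit.

The compounds shown leave open whether the added carbonyl or the exchange of chlorine for methyl matters here. A 2-chlorobenzoyl group on the same nitrogen would separate these two changes.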